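This account rests on a few compounds, and the source may have more. Where it says the series, first, only, none or still open, it means among the compounds named here.

In a functional assay for activation of Alpha-1D adrenergic receptor (Homo sapiens), read by calcium flux (on this read-out higher numbers stand for an effect only at larger amounts of compound and lower numbers for an effect already at smaller amounts), three compounds have been examined so far, each built on a shared core that carries an aromatic group. Compound 1 `Cc1ccnc(-c2ccccc2OCC2=NCCN2)c1` gives < 100000 nM in this assay, and that is a limit of the assay rather than a number. Compound 2 `Cc1cccc(-c2ccccc2OCC2=NCCN2)n1` likewise gives < 100000 nM in this assay, again a limit. Within the data shown here, compound 3 `c1csc(-c2ccccc2OCC2=NCCN2)c1` is the one compound with a measured number: in this assay it gives 15.9 nM. Among the measured compounds shown here, it therefore stands alone, because the two other values are limits the limit of < 100000 nM in this assay, at which 2 of the 3 values shown sit, and offer no figure to set beside it, so no step between measured compounds can be drawn.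

Compound 4 `Cc1cnsc1-c1ccccc1OCC1=NCCN1` has not yet been measured. It differs from compound 3 in a single place: 4-methyl-1,2-thiazol-5-yl in place of thiophen-2-yl on an aromatic carbon No measured step of this kind exists among the compounds shown, so nothing fixes the size of the change in advance. A small step is expected, of about the size of the usual scatter or a little beyond it, and it is expected to run toward an effect only at somewhat larger amounts of compound, a 2.5-fold higher number from compound 3 to compound 4 (0.40 log units; beyond the scatter). For compound 4 the estimate in this assay is 40 nM, with a range from 8 nM to 200 nM.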

Compound 4, half-maximal effective concentration: < 100000 nM
Compound 4 ended at the assay's limit; the forecaster's own chance of this, stated with the estimate: 5%; the middle value lies beyond the limit too.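

In this assay, compound 4 gives < 100000 nM, which is a limit of the assay and not a number. No size can therefore be read for the step from compound 3 to compound 4, because only one value is an actual number: the limit of < 100000 nM in this assay, at which 3 of the 4 values shown sit.

The compounds shown leave open whether the methyl group or the extra ring nitrogen of 4-methyl-1,2-thiazol-5-yl, taken alone, would give the same result.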